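Series notes: xanthine-type adenosine A2b ligands, methylation step

The source may hold more compounds than are shown below. What is called first, only, known or untested is meant among the compounds shown, and "the series" means these compounds.

Three compounds have numbers in an assay on HEK293 cells for binding affinity to adenosine receptor A2b (Homo sapiens), read by radioligand binding; on this read-out lower numbers stand for stronger inhibition and higher numbers for weaker inhibition. Compound 1 `C=CCn1c(=O)[nH]c2[nH]cnc2c1=O` gives 461 nM, compound 2 `CC(C)CCn1c(=O)c2nc[nH]c2n(CC(C)C)c1=O` gives 6240 nM, and compound 3 `C=CCn1c(=O)c2[nH]c(-c3ccccc3)nc2n(C)c1=O` gives 37 nM. Compound 3 thus holds the lowest number of the three, beyond the scatter from both compound 1 and compound 2, and by that standing it is the strongest binder shown. For the measured compounds named here, no two of the measured compounds differ in only one place, so no single-change step between measured compounds is available.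

Compound 4 `C=CCn1c(=O)c2c(nc(-c3ccccc3)n2C)n(C)c1=O` is not yet measured. It differs from compound 3 by methyl in place of hydrogen on an aromatic nitrogen. Going by the values given here, no measured pair shows this change, and its size in this assay cannot be read from the numbers above. Because compound 3 already gives 37 nM, the expectation is a step from compound 3 to compound 4 toward a weaker number, estimated at an 11-fold higher number from compound 3 to compound 4 (1.03 log units; beyond the scatter). Compound 4 is expected at 400 nM, within a range of 90 nM to 3000 nM.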

Compound 4, inhibition constant: 11400 nM
Compound 4: the middle estimate sits 29-fold (1.45 log units) below what was measured; the whole stated range lies below it.
By their numbers in this assay, from the lowest: compound 3; then compound 1; then compounds 2 and 4 (each within the scatter of the next).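

In this assay the change of methyl in place of hydrogen on an aromatic nitrogen, next to the ring atom that bears a phenyl group, gives a 310-fold higher number from compound 3 to compound 4 (2.49 log units; beyond the scatter) as a large step beyond the scatter. The earlier compounds shown here offered no pair that isolated any single position, and this pair shows that one added carbon on this nitrogen is enough to move the number that far, with the hydrogen form holding the stronger value. Nothing measured here accounts for the size of this step.

The compounds shown leave open whether ethyl, a longer chain or a chain ending in a carboxylic acid on this nitrogen would give a step of similar size. They also leave open whether the step would persist with an amine in place of the phenyl group.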